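The compounds below may be only part of what the source reports. "The series", "measured", "known", "first", "only" and "open" are said of these compounds alone.

Working notes on the series. The read-out throughout is a functional assay on the whole organism (blood) with Rattus norvegicus as the target, with stated times of 24 h and 1 h, at a dose of 1 mg/kg by the intraperitoneal route; on this read-out higher numbers stand for a stronger effect at the one dose given and lower numbers for a weaker effect. Compound 1 `COc1ccc(Cl)cc1C(=O)NCCC1CCN(S(=O)(=O)NC(=O)NC2CCCCC2)CC1` gives 39% in this assay. Compound 2 `O=C(NC[C@@H]1C[C@@H]2C=C[C@@H]1C2)NS(=O)(=O)N1CCC(CCNC(=O)c2cc(Cl)ccn2)CC1` gives 16% in this assay, the lower of the two numbers; the gap up to compound 1 lies beyond the scatter, and since the two structures differ in several places at once, only the two values themselves can be set side by side. Compound 3 `Cn1cc(C(=O)NCCC2CCN(S(=O)(=O)NC(=O)NC[C@@H]3C[C@@H]4C=C[C@@H]3C4)CC2)c(=O)n(C)c1=O` has not yet been measured in this assay. Relative to compound 2 it carries a group of 10 heavy atoms (6 carbon, 2 nitrogen, 2 oxygen; one six-membered aromatic ring with 2 hetero atoms) in place of a group of 7 heavy atoms (5 carbon, 1 nitrogen, 1 chlorine; one six-membered aromatic ring with 1 hetero atom), on a carbonyl carbon. Among the compounds with values here, no single-point step is known, so the size of this change is open. On what compound 2 shows, the step from compound 2 to compound 3 is expected to be small, a number 4 percentage points higher from compound 2 to compound 3 (within the scatter), and not clearly beyond the scatter in either direction. Compound 3 is accordingly estimated at 20% in this assay, within a range from 5% to 45%.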

Compound 3, a percentage reported as activity, at one dose (the size of the read-out at that dose, not a potency): 12%
Compound 3: middle estimate off by 8 percentage points, on the high side; the measured number falls inside the stated range.
By their numbers in this assay, from the lowest: compounds 3 and 2 (each within the scatter of the next); then compound 1.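

Within the data shown here, this is the first single-point step: at the carbonyl carbon, whose other neighbour is an amide-type nitrogen, this assay gives a number 4 percentage points lower from compound 2 to compound 3 (within the scatter). Replacing 4-chloropyridin-2-yl with a chlorine-free group of 10 heavy atoms, which has 4 hydrogen-bond acceptors rather than 1, therefore leaves compound 2 and compound 3 indistinguishable on this read-out, so this exchange at this position does not separate them. No measurement at hand explains why the two groups read alike.

As far as these compounds go, whether a simple phenyl, a carboxylic acid or an amine on this carbonyl carbon would move the number beyond the scatter remains open. Compound 1 gives 39%, but it differs from the other two compounds in several places, so no single change can account for that value.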